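Working notes: from compound 1 to compound 4

The source may hold more compounds than are shown below. What is called first, only, known or untested is meant among the compounds shown, and "the series" means these compounds.

Measured in a physicochemical assay for solubility, measured as kinetic solubility, with a stated time of 1 h, at pH 7.4; a higher number here means a more soluble compound, a lower number a less soluble compound:
- compound 1 `CC(=O)Nc1nc(-c2ccc(Cl)c(Cl)c2)cs1`: < 1000 nM, a limit of the assay
- compound 2 `O=C(Nc1nc(-c2ccc(Cl)c(Cl)c2)cs1)C1CC1`: 3000 nM
- compound 3 `O=C(Nc1nc(-c2ccc(Cl)c(Cl)c2)cs1)c1cncs1`: 2000 nM

Compound 1 gives only a limit and no number, and it stands at the limit of < 1000 nM in this assay, at which 1 of the 3 values shown sits. Compound 4 `CC(=O)Nc1nc(-c2ccc(Cl)c(F)c2)cs1` carries fluoro in place of chloro on an aromatic carbon, ortho to a chloro group: fluoro in place of chloro on an aromatic carbon.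

Among the compounds with values here, no measured step touches the halogens. All three change the group on the carbonyl carbon, so they bear on this change only by showing how far values have moved in the series. Cyclopropyl in place of methyl gives an at least 3.0-fold higher number from compound 1 to compound 2 (0.47 log units; beyond the scatter). 1,3-thiazol-5-yl in place of methyl gives an at least 2.0-fold higher number from compound 1 to compound 3 (0.30 log units; that floor lies within the scatter). 1,3-thiazol-5-yl in place of cyclopropyl gives a 1.5-fold lower number from compound 2 to compound 3 (0.18 log units; within the scatter).

Within the data shown here, with no halogen step measured, the change in this assay is expected to be no larger than these, and upward if it shows at all. A result reported only as a limit would not be a surprise. The expected step is a number no lower from compound 1 to compound 4 (the limit leaves the size open). Compound 4 is estimated at 1000 nM, with an expected range of 400 nM to 3000 nM.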

Compound 4, solubility: 5000 nM
Estimate against measurement, compound 4: 5.0-fold (0.70 log units) below, and the stated range ends below it.
By their numbers in this assay, from the lowest: compounds 3, 2 and 4 (each within the scatter of the next, the first and the last beyond it). At a limit, below all of these: compound 1.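

In this assay, the halogen on the aromatic ring proves to be a second place where values in this series can move, since all earlier steps changed only the group on the carbonyl carbon. Fluoro in place of chloro, ortho to a chloro group and meta to a group of 9 heavy atoms, gives an at least 5.0-fold higher number from compound 1 to compound 4 (0.69 log units; beyond the scatter), a step beyond the scatter from a change that leaves the group on the carbonyl carbon as it stands in compound 1. Compound 1 gives a limit of the assay and not a number, which leaves the true size of this step open and fixes only its floor: the limit of < 1000 nM in this assay, at which 1 of the 4 values shown sits.

Going by these compounds, it remains open whether fluoro in place of chloro gives a comparable step with cyclopropyl or 1,3-thiazol-5-yl on the carbonyl carbon, as the exchange is read here only with the methyl group of compound 1. Also open, on these data alone, are how the remaining chloro group contributes and how other groups at this position, such as a methoxy group, a nitrile or an amine, would read in this assay.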